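The compounds below may be only part of what the source reports. "The series", "measured", "known", "first", "only" and "open" are said of these compounds alone.

In a functional assay on DLD-1 cells (Homo sapiens) for cytotoxicity, read by resazurin assay, with a stated time of 48 h (on this read-out higher numbers stand for an effect only at larger amounts of compound and lower numbers for an effect already at smaller amounts), compound 1 `COc1ccc(S(=O)(=O)Nc2ccc(-c3nc4cc(NS(=O)(=O)c5ccc(OC)cc5)ccc4o3)cc2)cc1` gives 28000 nM and compound 2 `O=S(=O)(Nc1ccc(-c2nc3cc(NS(=O)(=O)c4cccc5ccccc45)ccc3o2)cc1)c1cccc2ccccc12` gives 34000 nM, two values within the scatter of each other. Compound 3 `COc1ccc(S(=O)(=O)Nc2ccc3oc(-c4ccc(NS(=O)(=O)c5cc(Br)ccc5OC)cc4)nc3c2)cc1` is not yet measured. It differs from compound 1 by 5-bromo-2-methoxyphenyl in place of 4-methoxyphenyl on a sulfonyl sulfur, with 5-bromo-2-methoxyphenyl in place of 4-methoxyphenyl on a sulfonyl sulfur. Going by the values given here, no measured pair isolates this change, so no step beyond the scatter is expected in this assay. The estimated step is a 1.2-fold lower number from compound 1 to compound 3 (0.07 log units; within the scatter). The expected value for compound 3 is 24000 nM, with an estimated range of 9000 nM to 60000 nM.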

Compound 3, half-maximal effective concentration: 15000 nM
Estimate against measurement, compound 3: 1.6-fold (0.20 log units) above; low and high end bracket the measured number.
By their numbers in this assay, from the lowest: compounds 3, 1 and 2 (each within the scatter of the next, the first and the last beyond it).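

In this assay, going by these compounds alone, replacing 4-methoxyphenyl with 5-bromo-2-methoxyphenyl on one sulfonyl sulfur gives a 1.9-fold lower number from compound 1 to compound 3 (0.27 log units; within the scatter), the first step that isolates a single place. At this sulfonyl sulfur, the aryl group can therefore carry bromine and a differently placed methoxy without a step beyond the scatter.

The compounds shown leave open whether the bromine and the methoxy placement would act alike when changed separately, and whether a carboxylic acid or an amine on this ring would give a step beyond the scatter. No measured property bears on this result.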